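The source may hold more compounds than are shown below. What is called first, only, known or untested is meant among the compounds shown, and "the series" means these compounds.

Measured so far:
compound 1 `O=C1c2ccccc2S(=O)(=O)N1CCCCCN1CCN(c2ccc(Cl)cc2)CC1` — 703 nM
compound 2 `O=C1c2ccccc2S(=O)(=O)N1CCCCCCN1CCN(c2ncccn2)CC1` — 5710 nM
compound 3 `COc1ccccc1N1CCN(CCCCCCN2C(=O)c3ccccc3S2(=O)=O)CC1` — 779 nM

In an assay on HEK293 cells for displacement of a labelled ligand from 5-hydroxytryptamine receptor 6 (Homo sapiens) (a lower number here means a stronger inhibitor, a higher number a weaker inhibitor), compound 1 gives the lowest of the three numbers; compound 3 sits within the scatter of it, whereas compound 2 lies well beyond it and is the highest of the set. Compound 4 `O=C1c2ccccc2S(=O)(=O)N1CCCCCN1CCN(c2ncccn2)CC1` keeps the shared core and the chain of compound 1 and carries pyrimidin-2-yl in place of 4-chlorophenyl on an amine nitrogen in a ring. For the measured compounds named here, one measured step bears on this change, run in the opposite direction on the longer chain: a 7.3-fold lower number from compound 2 to compound 3 (0.87 log units; beyond the scatter). Compound 2, which already carries the pyrimidin-2-yl, confirms the direction. A rise of similar size is therefore expected for compound 4, a 6.4-fold higher number from compound 1 to compound 4 (0.81 log units; beyond the scatter), beyond the scatter. Compound 4 is estimated at 4500 nM, with a range of 1500 nM to 13000 nM.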

Compound 4, inhibition constant: 7100 nM
The estimate for compound 4 lay 1.6-fold (0.20 log units) below the measured number, and the stated range covers the measured number.
By their numbers in this assay, from the lowest: compounds 1 and 3 (each within the scatter of the next); then compounds 2 and 4 (each within the scatter of the next).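

In this assay, pyrimidin-2-yl in place of 4-chlorophenyl on an amine nitrogen in a ring gives a 10-fold higher number from compound 1 to compound 4 (1.00 log units; beyond the scatter). The earlier step, a 7.3-fold lower number from compound 2 to compound 3 (0.87 log units; beyond the scatter), compared pyrimidin-2-yl only with 2-methoxyphenyl on the longer chain; pyrimidin-2-yl now also gives the higher number against 4-chlorophenyl on the shorter chain, and compounds 2 and 4 stand within the scatter of each other. No measurement on hand accounts for this change. Open, going by these compounds, is where pyridin-2-yl or unsubstituted phenyl would fall at this nitrogen on either chain.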